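Amide aryl swap on the shared core: pyridyl to chlorophenyl

A few compounds are considered here, and "the series" means these few. Any claim that something is new, unique, unknown or untested is made for them only; others in the source may bear on it.

The series keeps one core, seen in compound 1 `O=C(Nc1ccc(Cl)c(-c2nnc3c(Cl)cccn23)c1)c1ccccn1`, and varies the aryl on the amide carbonyl. For the measured compounds named here, in a functional assay on HeLa cells (Homo sapiens) for antiproliferative activity, read by MTT assay, with a stated time of 72 h (on this read-out lower numbers stand for stronger inhibition and higher numbers for weaker inhibition), compound 1 gives 75500 nM, one of only two numbers obtained; the other belongs to compound 3 `CS(=O)(=O)c1cccc(C(=O)Nc2ccc(Cl)c(-c3nnc4c(Cl)cccn34)c2)c1`, which gives 86400 nM, and the two sit within the scatter of each other. The step of a 1.1-fold higher number from compound 1 to compound 3 (0.06 log units; within the scatter) shows that 3-(methylsulfonyl)phenyl in place of pyridin-2-yl on a carbonyl carbon leaves the read-out where it was. Compound 2 `CS(=O)(=O)c1ccc(C(=O)Nc2ccc(Cl)c(-c3nnc4c(Cl)cccn34)c2)c(Cl)c1` gives only a limit in this assay, > 100000 nM.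

Compound 4 `O=C(Nc1ccc(Cl)c(-c2nnc3c(Cl)cccn23)c1)c1ccccc1Cl` carries the change (2-chlorophenyl in place of pyridin-2-yl on a carbonyl carbon). Going by the values given here, the one measured step at the same place, from compound 1 to compound 3, stayed within the scatter, and no other pair in the set differs in one place. For compound 4 the expected step is therefore a 1.2-fold higher number from compound 1 to compound 4 (0.08 log units; within the scatter) in this assay, nothing beyond the scatter. The estimate for compound 4 is 90000 nM, with a range from 40000 nM to 200000 nM. Because compound 2 already sits at the limit of > 100000 nM in this assay, at which 1 of the 3 values shown sits, a fair share of outcomes for compound 4 could again be a limit rather than a number.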

Compound 4, half-maximal inhibitory concentration: > 100000 nM
Compound 4: only a limit was reported (the forecaster's own chance of this, stated with the estimate: 40%); middle value at least 1.1-fold (0.04 log units) away from the limit.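

In this assay compound 4 gives > 100000 nM, which is a limit and not a number. Against the two compounds with numbers, the result reads as an at least 1.3-fold higher number from compound 1 to compound 4 (0.12 log units; that floor lies within the scatter) and as an at least 1.1-fold higher number from compound 3 to compound 4 (0.06 log units; that floor lies within the scatter), so both floors stay within the scatter and no real loss is established at this place on the carbonyl carbon, although the true size of either step may be larger. What is new is that 2-chlorophenyl without the methylsulfonyl group of compound 2 also gives no number, and the step between compound 2 and compound 4 cannot be read, which leaves the two chlorine-bearing aryl amides at the top of the range and the series increasingly bounded by the assay limit: the limit of > 100000 nM in this assay, at which 2 of the 4 values shown sit.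

From the compounds shown here alone, what an amine or a carboxylic acid on this aryl ring would do to the read-out remains open, as does the effect of moving from pyridin-2-yl to a simple unsubstituted phenyl. Going by these compounds, how far compound 2 and compound 4 actually lie past the limit also remains unknown, so the chlorine-bearing pair cannot yet be ranked against compound 1 or compound 3.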